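Bromo to Methyl on the Anilide Ring: An Expected Value

A few compounds are considered here, and "the series" means these few. Any claim that something is new, unique, unknown or untested is made for them only; others in the source may bear on it.

Compound 2, `CO/C(=C\c1ccc(OC)cc1)C(=O)Nc1ccc(Br)cc1`: 1770 nM
Compound 1, `CO/C(=C\c1ccc(Br)cc1)C(=O)Nc1ccc(C)cc1`: 12900 nM

In a functional assay on cells (Splenocyte, Mus musculus, strain BALB/c) for inhibition, read by MTT assay, with a stated time of 48 h (on this read-out higher numbers stand for weaker inhibition and lower numbers for stronger inhibition), compound 2 stands lowest of the two numbers. Compound 1 gives 12900 nM, a gap beyond the usual scatter. Compound 3, `CO/C(=C\c1ccc(OC)cc1)C(=O)Nc1ccc(C)cc1`, is not yet measured; it differs from compound 2 in one place only: methyl in place of bromo on an aromatic carbon. Among the measured compounds shown here, no measured pair shows this single change, so the direction rests on the change alone. Compound 3 is expected to move modestly toward weaker inhibition, a 2.0-fold higher number from compound 2 to compound 3 (0.30 log units; within the scatter). The estimate for compound 3 is 3500 nM, with a range from 1200 nM to 12000 nM.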

Compound 3, half-maximal inhibitory concentration: 940 nM
The estimate for compound 3 lay 3.7-fold (0.57 log units) above the measured number, outside the stated range (below it).
By their numbers in this assay, from the lowest: compounds 3 and 2 (each within the scatter of the next); then compound 1.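

In this assay, methyl in place of bromo at this position gives a 1.9-fold lower number from compound 2 to compound 3 (0.27 log units; within the scatter), so this position shows no clear preference between the two groups. The larger difference lies at the other ring, where methoxy in place of bromo gives a 14-fold lower number from compound 1 to compound 3 (1.14 log units; beyond the scatter). Nothing measured here explains either step. Still open, on these data alone, is whether this position accepts groups unlike these two, such as an amine, a carboxylic acid or a longer chain. As far as these compounds go, whether methoxy alone at this position would match bromo and methyl also remains unknown.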